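The compounds below may be only part of what the source reports. "The series", "measured", "known", "first", "only" and "open" are said of these compounds alone.

Compound 1 `COc1nc2ccc(Br)cc2cc1C(c1ccccc1)n1cc(-c2ccc(Br)cc2)nn1` and compound 2 `COc1nc2ccc(Br)cc2cc1C(c1ccccc1)n1cc(-c2ccccc2)nn1` share one core and differ only in a bromo against a hydrogen on an aromatic carbon. In an ADME assay on PC-3 cells (Homo sapiens) for cytotoxicity, read by sulforhodamine B assay, with a stated time of 48 h, tested at 10 uM (on this read-out higher numbers stand for more inhibition at the one concentration tested (going by the name of the read-out) and lower numbers for less inhibition), compound 1 gives 7.43%, and in this assay compound 2 gives 5.97%. Among the compounds with values here, the step of a number 1.5 percentage points lower from compound 1 to compound 2 (within the scatter) is the only measured step, and it leaves compound 2 with the lowest of the two numbers, its nearest neighbour being compound 1 at a gap within the scatter. Compound 3 `CCCCc1cn(C(c2ccccc2)c2cc3cc(Br)ccc3nc2OC)nn1` is reached from compound 2 by the change (butyl in place of phenyl on an aromatic carbon). Within the data shown here, no measured step bears on this change; the single measured step, a number 1.5 percentage points lower from compound 1 to compound 2 (within the scatter), concerned a hydrogen in place of bromo and stayed within the scatter, and both measured numbers are low. For compound 3 the step of a number 1 percentage points higher from compound 2 to compound 3 (within the scatter) is therefore expected to stay within the scatter, with no direction favoured. Compound 3 is estimated to give 7% in this assay, within a range from -6% to 22%.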

Compound 3, a percentage reported as inhibition, at one concentration (the size of the read-out at that concentration, not a potency): 5.54%
Compound 3: middle estimate off by 1.5 percentage points, on the high side; low and high end bracket the measured number.
By their numbers in this assay, from the lowest: compounds 3, 2 and 1 (each within the scatter of the next).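

In this assay, butyl in place of phenyl on the five-membered aromatic ring gives a number 0.4 percentage points lower from compound 2 to compound 3 (within the scatter) and butyl in place of 4-bromophenyl gives a number 1.9 percentage points lower from compound 1 to compound 3 (within the scatter), so both steps stay within the scatter. The earlier pair varied only a bromo on the phenyl, whereas these steps show that the whole aromatic ring at this position can give way to an open chain with no change beyond the scatter, and all three numbers remain low. Nothing at hand offers an explanation for this result.

On these data alone, whether an amine, a carboxylic acid or a chain longer than butyl at this position would move the number beyond the scatter remains open. So does whether replacing the methoxy on the shared core would do so.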